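Trifluoromethyl for Methyl on the Pendant Aryl Group

The source may report more compounds than this note shows. Statements on the series, on what has been measured and on what is new or still open speak of the compounds shown alone.

Compound 1, `CCC1=C(O)c2c(oc(-c3cccc(C)c3)cc2=O)C(CC)(CC)C1=O`: 3.69 uM
Compound 2, `CCC1=C(O)c2c(oc(-c3cccc(C(F)(F)F)c3)cc2=O)C(CC)(CC)C1=O`: 5.42 uM
Compound 3, `CCC1=C(O)c2c(oc(-c3ccccc3C)cc2=O)C(CC)(CC)C1=O`: 2.41 uM

All three were tested in a functional assay on KBVIN cells (Homo sapiens) for antiproliferative activity, read by sulforhodamine B assay, with a stated time of 3 days; a higher number here means that more compound is needed for the effect, a lower number that less compound is needed. Compound 1 and compound 2 differ by trifluoromethyl in place of methyl on an aromatic carbon, which gave a 1.5-fold higher number from compound 1 to compound 2 (0.17 log units; within the scatter). Compound 1 and compound 3 differ by 2-methylphenyl in place of 3-methylphenyl on an aromatic carbon, with a 1.5-fold lower number from compound 1 to compound 3 (0.19 log units; within the scatter). Compound 4, `CCC1=C(O)c2c(oc(-c3ccccc3C(F)(F)F)cc2=O)C(CC)(CC)C1=O`, has not been measured; it differs from compound 3 by trifluoromethyl in place of methyl on an aromatic carbon. This is the same kind of change as that from compound 1 to compound 2, but here the entering group sits ortho to a large group, whereas before it sat meta to a large group. The step expected in this assay is a 1.5-fold higher number from compound 3 to compound 4 (0.17 log units; within the scatter), resting on the fact that a 1.5-fold higher number from compound 1 to compound 2 (0.17 log units; within the scatter) was within the scatter. Compound 4 is therefore estimated at 3.6 uM in this assay, with an expected range from 1.8 uM to 7.5 uM.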

Compound 4, concentration for half-maximal effect: 43.1 uM
Beside the measured number, compound 4's estimate is 12-fold (1.08 log units) below it, outside the stated range (above it).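

In this assay, trifluoromethyl in place of methyl on an aromatic carbon ortho to a large group gave an 18-fold higher number from compound 3 to compound 4 (1.25 log units; beyond the scatter) and so the step seen on one core did not carry over to the other: the same change on two cores in this assay, a 1.5-fold higher number (0.17 log units; within the scatter) from compound 1 to compound 2 and an 18-fold higher number (1.25 log units; beyond the scatter) from compound 3 to compound 4, 12-fold (1.09 log units) apart, beyond the scatter of two such steps. A step within the scatter on one core was therefore no guide to the size of the same change on the other core in this series. Among these compounds, this does not show why the two steps differ, and with only one pair on each core it gives no rule for any further core.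

The compounds shown leave open how a chlorine, a methoxy group or an ethyl chain at that same place would compare with methyl and trifluoromethyl. They also leave open whether the large step recurs in another cell line.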